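The source may report more compounds than this note shows. Statements on the series, on what has been measured and on what is new or still open speak of the compounds shown alone.

In a functional assay on HGC-27 cells (Homo sapiens) for inhibition, read by MTT assay, with a stated time of 72 h (on this read-out lower numbers stand for stronger inhibition and higher numbers for weaker inhibition), compound 1 (`COc1ccc(N2CCCC2)c(C(=O)Nc2ccc(CNC(=O)OCc3cccnc3)cc2)c1`) gives 138000 nM and compound 2 (`O=C(NCc1ccc(NC(=O)c2cc(Cl)ccc2N2CCCC2)cc1)OCc1cccnc1`) gives 750 nM as the lower of the two numbers, so compound 2 is the stronger inhibitor of this pair. Compound 3 (`O=C(NCc1ccc(NC(=O)c2cc(C(F)(F)F)ccc2N2CCCC2)cc1)OCc1cccnc1`) keeps the rest of compound 2 but carries trifluoromethyl in place of chloro on an aromatic carbon at the same place. Going by the values given here, the only measured step at that place is a 180-fold lower number from compound 1 to compound 2 (2.26 log units; beyond the scatter) for chloro in place of methoxy, and it is large. Among the compounds with values here, no measured compound carries trifluoromethyl, so this step shows only that a change here can move the number strongly and gives no direction for the new group. Within the data shown here, no step of that size is expected in this assay, and the best guess is a change within the scatter, in neither direction. The expected step is a 1.1-fold higher number from compound 2 to compound 3 (0.03 log units; within the scatter) and remains uncertain. The estimate for compound 3 is 800 nM with an expected range from 250 nM to 2500 nM for repeated measurements.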

Compound 3, half-maximal inhibitory concentration: 790 nM
Compound 3: the middle estimate sits 1.0-fold (0.01 log units) above what was measured; the range from low to high includes it.
By their numbers in this assay, from the lowest: compounds 2 and 3 (each within the scatter of the next); then compound 1.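

Trifluoromethyl at this place, on an aromatic carbon para to a pyrrolidin-1-yl group, gives a 1.1-fold higher number from compound 2 to compound 3 (0.02 log units; within the scatter) even though it brings 4 heavy atoms where chloro had 1, so this exchange leaves the number within the scatter. The large drop seen earlier is therefore not tied to chloro alone, since replacing methoxy with trifluoromethyl gives a 170-fold lower number from compound 1 to compound 3 (2.24 log units; beyond the scatter) and so a second group also lands far from methoxy. No measured evidence is available to explain why chloro and trifluoromethyl match here or why methoxy stands so far from both.

On these data alone, what remains open is where other groups would fall: a nitrile, a fluoro or an amine at this place could sit with compound 2 and compound 3 or with compound 1. As far as these compounds go, it is also open whether exchanging chloro for trifluoromethyl would leave the number as unchanged elsewhere on the shared core.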